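Swapping the Basic Amine Chain for a Hydroxymethyl Group

The source may report more compounds than this note shows. Statements on the series, on what has been measured and on what is new or still open speak of the compounds shown alone.

In a functional assay on MCF7 cells (Homo sapiens) for antiproliferative activity, read by MTT assay, with a stated time of 48 h (a lower number here means a stronger inhibitor, a higher number a weaker inhibitor), compound 1 `CCn1c(C(=O)NCCCN(C)C)ccc1C(CC)(CC)c1ccc(OCCC(O)(CC)CC)c(C)c1` gives 3350 nM, the lowest of the two numbers recorded here. Compound 3 `CCC(C)C(NC(=O)c1ccc(C(CC)(CC)c2ccc(OCCC(O)(CC)CC)c(C)c2)n1CC)C(=O)O` gives 11300 nM. Compound 2 `CCn1c(C(=O)NCC#N)ccc1C(CC)(CC)c1ccc(OCCC(O)(CC)CC)c(C)c1` reaches only the assay limit of > 50000 nM and so has no number. The nearest measured change is a 3.4-fold higher number from compound 1 to compound 3 (0.53 log units; beyond the scatter), while an at least 14-fold higher number from compound 1 to compound 2 (1.17 log units; beyond the scatter) is the largest. Compound 4 `CCC(C)C(CO)NC(=O)c1ccc(C(CC)(CC)c2ccc(OCCC(O)(CC)CC)c(C)c2)n1CC` has not yet been measured. It differs from compound 1 by 1-(hydroxymethyl)-2-methylbutyl in place of 3-(dimethylamino)propyl on an amide-type nitrogen. The step that bears most closely on it is a 3.4-fold higher number from compound 1 to compound 3 (0.53 log units; beyond the scatter), where the same 3-(dimethylamino)propyl was also replaced on the amide-type nitrogen, so a modest weakening is expected. Compound 4 is therefore estimated to give 8000 nM, within 3000 nM to 25000 nM, which means an expected step of a 2.4-fold higher number from compound 1 to compound 4 (0.38 log units; beyond the scatter).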

Compound 4, half-maximal inhibitory concentration: 29100 nM
Beside the measured number, compound 4's estimate is 3.6-fold (0.56 log units) below it; the whole stated range lies below it.
By their numbers in this assay, from the lowest: compound 1; then compound 3; then compound 4. At a limit, above all of these: compound 2.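

At the amide-type nitrogen in this assay, the new chain falls well short of 3-(dimethylamino)propyl: an 8.7-fold higher number from compound 1 to compound 4 (0.94 log units; beyond the scatter). On the branched chain itself, the group on the saturated chain carbon also matters, with hydroxymethyl in place of carboxy giving a 2.6-fold higher number from compound 3 to compound 4 (0.41 log units; beyond the scatter). Compound 2 stands at a limit of the assay, so an at least 1.7-fold lower number from compound 2 to compound 4 (0.23 log units; that floor lies within the scatter) gives only a floor: the limit of > 50000 nM in this assay, at which 1 of the 4 values shown sits.

The compounds shown leave open whether an amine in place of the hydroxymethyl on the branched chain would match compound 1. They also leave open how a longer chain ending in dimethylamino would compare.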